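Notes on adding cyano to compound 2

The source may report more compounds than this note shows. Statements on the series, on what has been measured and on what is new or still open speak of the compounds shown alone.

Measured in a physicochemical assay for solubility; on this read-out higher numbers stand for higher solubility and lower numbers for lower solubility:
- compound 1 `C[C@@H]1CN(c2c(C#N)c(C(F)(F)F)nn2-c2ccc(S(C)(=O)=O)cn2)[C@H](C)CO1`: > 200 ug/mL
- compound 2 `CC1CCCN(c2cc(C(F)(F)F)nn2-c2ccc(S(C)(=O)=O)cn2)C1`: "not determined" (no result reported)

Compound 2 has no single number in this assay, which leaves it unplaced. Compound 1 also carries cyano, and its > 200 ug/mL is a limit of the assay, not a number. The unmeasured compound 3 `CC1CCCN(c2c(C#N)c(C(F)(F)F)nn2-c2ccc(S(C)(=O)=O)cn2)C1` comes next. The change cyano in place of hydrogen on an aromatic carbon puts cyano in place of hydrogen on an aromatic carbon. Among the compounds with values here, with no value on compound 2, no step of a particular size or direction is expected in this assay beyond the scatter. For compound 3 the estimated value is 100 ug/mL, with an expected range of 25 ug/mL to 200 ug/mL.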

Compound 3, solubility: 100 ug/mL
Compound 3: the middle estimate sits on the measured number at the digits printed; measured number inside the range.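

In this assay compound 3 gives 100 ug/mL, the only number rather than a limit among the cyano compounds shown. With cyano kept in place, 3-methylpiperidin-1-yl on the aromatic carbon of compound 3 and the oxygen-bearing six-membered ring of compound 1 are separated by an at least 2.0-fold lower number from compound 1 to compound 3 (0.30 log units; that floor lies within the scatter). That step is only a floor, and it rests on a limit of the assay: the limit of > 200 ug/mL in this assay, at which 1 of the 3 values shown sits.

The step from hydrogen to cyano itself cannot be read, as compound 2 has no value. From the compounds shown here alone, how an amine or a carboxylic acid in place of cyano at this position would read on this assay remains open.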